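The source may report more compounds than this note shows. Statements on the series, on what has been measured and on what is new or still open speak of the compounds shown alone.

Measured so far in a functional assay on HepG2 cells (Homo sapiens) for cytotoxicity, tested at 12.5 uM; on this read-out higher numbers stand for a stronger effect at the one concentration tested and lower numbers for a weaker effect:
compound 1 `NC1=NN(c2ccccc2)C(=O)/C1=C/Nc1ccc(S(=O)(=O)Nc2ccccn2)cc1`, value 57.8%
compound 2 `Cc1cc(C)nc(NS(=O)(=O)c2ccc(N/C=C3/C(=N)N(c4ccccc4)N=C3N)cc2)n1`, value 64.1%
compound 3 `N=C1NN=C(N)/C1=C\Nc1ccc(S(=O)(=O)Nc2cnc3ccccc3n2)cc1`, value 55.3%

Compound 1 stands second highest of the three numbers in this assay. Its nearest neighbour is compound 3, whose value lies lower by a gap that is within the usual scatter; compound 2 lies higher, again by a gap within the scatter. For the measured compounds named here, no two of the measured compounds differ in one place only, so no step between measured compounds can be read off; the three values simply sit within the scatter of one another, and no ordering among them is claimed.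

Compound 4 `NC1=NN(c2ccccc2)C(=O)/C1=C/Nc1ccc(S(=O)(=O)Nc2cnc3ccccc3n2)cc1` has not yet been measured in this assay. Against compound 1 the change is quinoxalin-2-yl in place of pyridin-2-yl on a sulfonamide nitrogen. Compound 3 carries the same quinoxalin-2-yl group on a sulfonamide nitrogen, though on a different core, and in this assay compound 3 gives 55.3%, which is close to compound 1. On that basis the step from compound 1 to compound 4 is expected to stay within the scatter, in no particular direction: the expected step is a number 0.8 percentage points lower from compound 1 to compound 4 (within the scatter). For compound 4 the estimate in this assay is 57%, with a range from 45% to 69%.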

Compound 4, a percentage reported as activity, at one concentration (the size of the read-out at that concentration, not a potency): 65.3%
The estimate for compound 4 lay 8.3 percentage points below the measured number, and the stated range covers the measured number.
By their numbers in this assay, from the lowest: compounds 3, 1, 2 and 4 (each within the scatter of the next).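

In this assay, for the compounds shown here, quinoxalin-2-yl in place of pyridin-2-yl on a sulfonamide nitrogen gives a number 7.5 percentage points higher from compound 1 to compound 4 (within the scatter) and provides the first comparison that differs in one place only. On the core of compound 1, this position therefore accepts quinoxalin-2-yl, with its additional six-membered aromatic ring of carbon only, and the read-out does not separate the two compounds. No measurement shown bears on the reason for this outcome.

The compounds shown leave open whether the same holds for other groups on the sulfonamide nitrogen, such as an acetyl group or a chain ending in a carboxylic acid, and whether a group with no aromatic ring, such as a plain methyl, would separate from compound 1 in this assay by more than the scatter. They also leave open how the effect at this one concentration relates to the effect at other concentrations, and whether quinoxalin-2-yl and pyridin-2-yl would compare in the same way on the other cores in the series.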